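Swapping the Amine End of a Biguanide Series

This account rests on a few compounds, and the source may have more. Where it says the series, first, only, none or still open, it means among the compounds named here.

Measured compounds:
- compound 1, `CCN(C)C(=N)NC(=N)Nc1ccc(C(F)(F)F)cc1`: 4100 nM in a functional assay on A549 cells (Homo sapiens) for antiproliferative activity, read by MTT assay, with a stated time of 72 h; on this read-out higher numbers stand for weaker inhibition and lower numbers for stronger inhibition
- compound 2, `CC(C)NC(=N)NC(=N)Nc1ccc(F)c(F)c1`: 5200 nM in this assay

Both measured compounds share a core built from two joined amidine units, capped at one end by a substituted phenyl ring and at the other by a small amine. In this assay compound 1 gives 4100 nM, and compound 2 gives 5200 nM. The two numbers sit close together: their gap lies within the usual scatter of repeated measurements, so the data do not separate the two compounds from each other. Compound 1 carries a trifluoromethyl group on the ring and an ethyl(methyl)amino group at the amine end; compound 2 carries two fluorine atoms on the ring and an isopropylamino group.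

The next compound, compound 3, `CC(C)NC(=N)NC(=N)Nc1ccc(C(F)(F)F)cc1`, keeps the trifluoromethyl ring of compound 1 and takes the amine end of compound 2. Compared with compound 1 the change is isopropylamino in place of ethyl(methyl)amino on a carbon with a double bond to nitrogen, so one hydrogen-bond donor appears at the carbon with a double bond to nitrogen while the atom count stays the same.

Among the compounds with values here, no pair of measured compounds differs in one place, so there is no measured step to lean on. Since compound 2, which already carries the isopropylamino group, gives 5200 nM, and compound 1 gives 4100 nM, the expectation is that the step from ethyl(methyl)amino to isopropylamino moves the number little, if at all, beyond the scatter. The estimated step is a 1.1-fold higher number from compound 1 to compound 3 (0.04 log units; within the scatter). Compound 3 is therefore expected to give about 4500 nM in this assay, with a likely range from 1800 nM to 11000 nM.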

Compound 3, half-maximal inhibitory concentration: 3600 nM
For compound 3 the middle estimate is 1.3-fold (0.10 log units) above the measured one; low and high end bracket the measured number.
By their numbers in this assay, from the lowest: compounds 3, 1 and 2 (each within the scatter of the next).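

Within the data shown here, for the first time, two compounds differ in one place only, so the amine end can be read on its own while the trifluoromethyl ring stays fixed. In this assay, putting isopropylamino in place of ethyl(methyl)amino is a 1.1-fold lower number from compound 1 to compound 3 (0.06 log units; within the scatter), so this pair shows that rearranging the same heavy atoms and gaining a hydrogen-bond donor on the carbon with a double bond to nitrogen leaves no change that can be told apart from ordinary repeat variation. No supporting measurement is available to explain why this swap makes so little difference.

As far as these compounds go, these two amine ends are close in size, so it remains open whether a clearly different group at this place, such as a longer chain like hexylamino or a plain unsubstituted amine, would move the number beyond the scatter. From the compounds shown here alone, it is also open whether a more drastic change elsewhere, such as a carboxylic acid on the ring in place of trifluoromethyl, would matter more than anything seen at the amine end.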